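The source may hold more compounds than are shown below. What is called first, only, known or untested is meant among the compounds shown, and "the series" means these compounds.

Measured in a functional assay on HeLa cells (Homo sapiens) for inhibition, read by MTT assay, with a stated time of 4 days; on this read-out higher numbers stand for weaker inhibition and lower numbers for stronger inhibition:
- compound 1 `COc1cc(NC(C)CCCNC(=O)NNC(=O)NCCCCCO)c2ncccc2c1`: >= 250000 nM (a limit)
- compound 2 `COc1cc(NC(C)CCCNC(=O)NNC(=O)NCCNC(c2ccccc2)(c2ccccc2)c2ccccc2)c2ncccc2c1`: 10000 nM
- compound 3 `COc1cc(NC(C)CCCNC(=O)NNC(=O)NCCCC(C)Nc2cc(OC)cc3cccnc23)c2ncccc2c1`: 67000 nM

Compound 1 stands at the limit of >= 250000 nM in this assay, at which 1 of the 3 values shown sits, so it has a limit and not a number. Compound 4 `COc1cc(NC(C)CCCNC(=O)Nc2ccc(Cl)c(C(F)(F)F)c2)c2ncccc2c1` has not yet been measured. It carries 4-chloro-3-(trifluoromethyl)phenyl in place of ((5-hydroxypentyl)carbamoyl)amino on an amide-type nitrogen, a change counted as 4-chloro-3-(trifluoromethyl)phenyl in place of ((5-hydroxypentyl)carbamoyl)amino on an amide-type nitrogen. Compound 2 gives 10000 nM and compound 3 gives 67000 nM, and both hold aromatic rings beyond the shared core, as compound 4 will. A large step towards stronger inhibition is therefore expected in this assay, though the basis is thin. The expected change is an at least 20-fold lower number from compound 1 to compound 4 (1.31 log units; beyond the scatter). For compound 4 the estimate is 12000 nM, with an expected range from 4000 nM to 40000 nM.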

Compound 4, half-maximal inhibitory concentration: 3900 nM
The estimate for compound 4 lay 3.1-fold (0.49 log units) above the measured number; the whole stated range lies above it.
By their numbers in this assay, from the lowest: compound 4; then compound 2; then compound 3. At a limit, above all of these: compound 1.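

In this assay, among these compounds, 4-chloro-3-(trifluoromethyl)phenyl in place of ((5-hydroxypentyl)carbamoyl)amino on an amide-type nitrogen gives an at least 64-fold lower number from compound 1 to compound 4 (1.80 log units; beyond the scatter), the first step that can be read at this place. It shows that a six-membered aromatic ring of carbon only, without hydrogen-bond donors, can stand here in place of a chain with no ring and give much stronger inhibition. The true size of the step stays unknown, since compound 1 stands at a limit and not at a number: the limit of >= 250000 nM in this assay, at which 1 of the 4 values shown sits.

The compounds shown leave open how much of the step belongs to the ring itself and how much to its substituents. A plain phenyl, or a phenyl carrying only chloro or only trifluoromethyl, would separate these.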